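Swapping chloro for fluoro on the aryl imine of compound 1

The compounds below may be only part of what the source reports. "The series", "measured", "known", "first", "only" and "open" are said of these compounds alone.

Measured compounds:
compound 1, `O=C1N/C(=N/c2ccc(Cl)cc2)S/C1=C\c1ccccn1`, 41.7%
compound 2, `Cc1cccc(/N=C2/NC(=O)/C(=C/c3ccccn3)S2)c1`, 52.3%
compound 3, `Cc1ccc(/N=C2/NC(=O)/C(=C/c3ccccn3)S2)cc1`, 43.2%

In a functional assay on the whole organism (strain Swiss albino) for inhibition, with Mus musculus as the target, in the writhing test, with stated times of 30 min and 15 min, at a dose of 50 mg/kg by the oral route (a lower number here means less inhibition, a higher number more inhibition at the dose given (going by the name of the read-out)), compound 1 gives 41.7%, the lowest of the three numbers. Its nearest neighbour is compound 3, with a number 1.5 percentage points higher from compound 1 to compound 3 (within the scatter); the furthest is compound 2, with a number 10.6 percentage points higher from compound 1 to compound 2 (beyond the scatter). Between compound 2 and compound 3 the record shows a number 9.1 percentage points lower from compound 2 to compound 3 (within the scatter).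

Compound 4, `O=C1N/C(=N/c2ccc(F)cc2)S/C1=C\c1ccccn1`, is not yet measured. It differs from compound 1 in one place: fluoro in place of chloro on an aromatic carbon, so that the 4-chlorophenyl becomes a 4-fluorophenyl. Among the compounds with values here, the measured step that bears most directly on this change is the one from compound 1 to compound 3, where another group replaced chloro on the same aromatic carbon and the outcome stayed within the scatter, a number 1.5 percentage points higher from compound 1 to compound 3 (within the scatter). The larger step to compound 2 involved a different position and does not speak to this exchange.

On that basis the expected step from compound 1 to compound 4 is small, a number 0.3 percentage points higher from compound 1 to compound 4 (within the scatter), with no change beyond the scatter expected. Compound 4 is therefore estimated at 42%, within a range from 32% to 52%.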

Compound 4, a percentage reported as inhibition, in the whole organism at one dose (the size of the read-out at that dose, not a potency): 43.2%
Beside the measured number, compound 4's estimate is 1.2 percentage points below it; the measured number falls inside the stated range.
By their numbers in this assay, from the lowest: compounds 1, 3, 4 and 2 (each within the scatter of the next, the first and the last beyond it).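

In this assay, fluoro in place of chloro on this aromatic carbon gives a number 1.5 percentage points higher from compound 1 to compound 4 (within the scatter), so an exchange of one halogen for another stays inside the scatter, as the earlier exchange of chloro for methyl did. Fluoro and methyl at this place cannot be told apart either, with no change at the digits printed from compound 3 to compound 4 (within the scatter), and the 4-fluorophenyl is not separated from the 3-methylphenyl, with a number 9.1 percentage points lower from compound 2 to compound 4 (within the scatter), although the 4-chlorophenyl is, with a number 10.6 percentage points higher from compound 1 to compound 2 (beyond the scatter). No measurement at hand offers an explanation for these results.

As far as these compounds go, it remains open whether an amine or a carboxylic acid on this aromatic carbon would move the number beyond the scatter. A 3-fluorophenyl also stands open, as the only position shown apart from this one carries methyl.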